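Replacing 2-hydroxyphenyl with 4-chlorophenyl: notes toward compound 3

This account rests on a few compounds, and the source may have more. Where it says the series, first, only, none or still open, it means among the compounds named here.

Measured in a functional assay, with a stated time of 10 min; on this read-out lower numbers stand for stronger inhibition and higher numbers for weaker inhibition:
- compound 1 `CN(C)c1ccc(-c2nc(NN)n(C)c(=O)c2C#N)cc1`: 66 ug/mL
- compound 2 `CCOC(=O)c1cnn(-c2nc(-c3ccccc3O)c(C#N)c(=O)n2C)c1N`: 58 ug/mL

Compound 2 stands within the scatter of compound 1, so these two values do not separate. Among the compounds with values here, no measured pair differs in only one place, which leaves the effect of any single change in this assay unknown.

Compound 3 `CCOC(=O)c1cnn(-c2nc(-c3ccc(Cl)cc3)c(C#N)c(=O)n2C)c1N` is compound 2 with 4-chlorophenyl in place of 2-hydroxyphenyl on an aromatic carbon. With compound 2 at 58 ug/mL as the only close reference, no step beyond the scatter is expected, and no direction is favoured. The expected change is a 1.1-fold lower number from compound 2 to compound 3 (0.02 log units; within the scatter), which is an estimate with little data behind it. For compound 3 the estimated value is 55 ug/mL, with an expected range of 22 ug/mL to 130 ug/mL.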

Compound 3, half-maximal inhibitory concentration: 94 ug/mL
For compound 3 the middle estimate is 1.7-fold (0.23 log units) below the measured one; low and high end bracket the measured number.
By their numbers in this assay, from the lowest: compounds 2, 1 and 3 (each within the scatter of the next).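

In this assay, within the data shown here, compounds 2 and 3 form the first pair that differs in one place, and the exchange gives a 1.6-fold higher number from compound 2 to compound 3 (0.21 log units; within the scatter) at this aromatic carbon, ortho to the cyano group. Among these compounds, replacing 2-hydroxyphenyl, with 1 hydrogen-bond donor and 1 hydrogen-bond acceptor, by 4-chlorophenyl, with 0 of each, therefore produces no step that can be told from the scatter. No supporting measurement is available to explain this result.

This single step alters the substituent and its place on the phenyl ring together, so the contribution of each remains unresolved. Going by these compounds, it also remains open whether unsubstituted phenyl, or a phenyl carrying an amine or a carboxylic acid, would give a step beyond the scatter at this position.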